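A few compounds are considered here, and "the series" means these few. Any claim that something is new, unique, unknown or untested is made for them only; others in the source may bear on it.

In a functional assay on MCF7 cells (Homo sapiens) for cytotoxicity, read by MTT assay, with a stated time of 72 h (on this read-out higher numbers stand for weaker inhibition and lower numbers for stronger inhibition), compound 1 `COc1cccc(/C=C2\CCC/C(=C\c3ccc(O)c(O)c3)C2=O)c1OC` gives 4700 nM. Compound 2 `COc1ccc(/C=C2\CCC/C(=C\c3cccc(Br)c3)C2=O)cc1OC` in this assay gives 5300 nM; of the two numbers shown it is the one nominally on top, but the gap to compound 1 is within the usual scatter, so the two compounds cannot be separated. Compound 3 `COc1ccc(/C=C2\CCC/C(=C\c3cc(Cl)cc(Cl)c3)C2=O)cc1OC` differs from compound 2 by 3,5-dichlorophenyl in place of 3-bromophenyl on a double-bonded chain carbon bound to a double-bonded ring carbon. Going by the values given here, no step between measured compounds is available for this change, so the expectation for compound 3 rests on compound 2, and the step from compound 2 to compound 3 is expected to be small, a 1.1-fold lower number from compound 2 to compound 3 (0.03 log units; within the scatter), not beyond the scatter. Compound 3 is estimated at 5000 nM, within a range from 2000 nM to 12000 nM.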

Compound 3, half-maximal inhibitory concentration: 3800 nM
Beside the measured number, compound 3's estimate is 1.3-fold (0.12 log units) above it; low and high end bracket the measured number.
By their numbers in this assay, from the lowest: compounds 3, 1 and 2 (each within the scatter of the next).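

In this assay the exchange of 3-bromophenyl for 3,5-dichlorophenyl on a double-bonded chain carbon bound to a double-bonded ring carbon gives a 1.4-fold lower number from compound 2 to compound 3 (0.14 log units; within the scatter) and so leaves the number at this position unchanged within the scatter. This position therefore accepts either of these two groups, and the series cannot separate them. Nothing at hand bears on the reason for this step. As far as these compounds go, whether a ring carrying an amine or a carboxylic acid, or a longer chain in place of the ring, keeps the number at this level remains open.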